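Compound 3 to compound 4: losing the sulfonyl group

This account rests on a few compounds, and the source may have more. Where it says the series, first, only, none or still open, it means among the compounds named here.

- compound 1 `N#CCC(=O)N/N=C1\C(=O)Nc2ccc(S(=O)(=O)N3CCOCC3)cc21`: 302000 nM
- compound 2 `O=C1Nc2ccc(S(=O)(=O)N3CCOCC3)cc2/C1=N/c1cccc(C(F)(F)F)c1`: 226000 nM
- compound 3 `Cc1ccc(S(=O)(=O)N/N=C2\C(=O)Nc3ccc(S(=O)(=O)N4CCOCC4)cc32)cc1`: 261000 nM

All three values come from an ADME assay on WI-38 cells (Homo sapiens) for cytotoxicity, read by sulforhodamine B assay, with a stated time of 24 h; a higher number here means a weaker inhibitor, a lower number a stronger inhibitor. For the measured compounds named here, there, compound 3 gives 261000 nM, which lies within the scatter of the values of both other compounds, so the series so far shows no separation.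

Compound 4 `N/N=C1\C(=O)Nc2ccc(S(=O)(=O)N3CCOCC3)cc21` is the next case. Its difference from compound 3 is hydrogen in place of (4-methylphenyl)sulfonyl on an amine nitrogen, in words hydrogen in place of (4-methylphenyl)sulfonyl on an amine nitrogen.

Going by the values given here, two measured steps bear on this. The closer one changes the group on that same amine nitrogen, a 1.2-fold lower number from compound 1 to compound 3 (0.06 log units; within the scatter). The other changes the group on the double-bonded nitrogen, a 1.3-fold lower number from compound 1 to compound 2 (0.13 log units; within the scatter). Among the compounds with values here, both are small, but no measured compound has hydrogen at this place, so the evidence is indirect.

No step beyond the scatter is expected in this assay, and the estimated step is a 1.1-fold lower number from compound 3 to compound 4 (0.04 log units; within the scatter). Compound 4 is estimated at 240000 nM, with an expected range of 120000 nM to 420000 nM.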

Compound 4, half-maximal inhibitory concentration: 391000 nM
Beside the measured number, compound 4's estimate is 1.6-fold (0.21 log units) below it; low and high end bracket the measured number.
By their numbers in this assay, from the lowest: compounds 2, 3, 1 and 4 (each within the scatter of the next).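

In this assay, hydrogen on the amine nitrogen gives a 1.5-fold higher number from compound 3 to compound 4 (0.18 log units; within the scatter) when it replaces (4-methylphenyl)sulfonyl and a 1.3-fold higher number from compound 1 to compound 4 (0.11 log units; within the scatter) when it replaces (cyanomethyl)carbonyl, so this place tolerates having no substituent at all without leaving the scatter. Set against the 3-(trifluoromethyl)phenyl group on the double-bonded nitrogen, the amino group gives a 1.7-fold higher number from compound 2 to compound 4 (0.24 log units; within the scatter) and the four compounds remain unseparated in this read-out. No evidence on what lies behind these small differences is at hand.

Still open, as far as these compounds go, is whether a carboxylic acid, a basic amine or a longer alkyl chain on this amine nitrogen would give a step beyond the scatter. From the compounds shown here alone, all four compounds also keep the shared core, so the effect of any change there remains unknown.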